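Exchanging the Pendant Aryl Group of a Bombesin Receptor Agonist

This account rests on a few compounds, and the source may have more. Where it says the series, first, only, none or still open, it means among the compounds named here.

Compound 1, `Cc1cccc(Cc2cnc(CCc3ccc(-c4ccccc4C(=O)O)cc3)[nH]2)c1`: 4310 nM
Compound 2, `N#Cc1ccc(Cc2cnc(CCc3ccc(-c4ccccc4C(=O)O)cc3)[nH]2)cc1`: 5890 nM

In an in vitro functional assay on cells for agonist activity at Bombesin receptor subtype-3 (Homo sapiens), read by luminescence and calcium flux (on this read-out higher numbers stand for an effect only at larger amounts of compound and lower numbers for an effect already at smaller amounts), compound 2 gives 5890 nM, the highest of the two numbers shown, with compound 1 its nearest neighbour. Going by the values given here, the only measured step is a 1.4-fold higher number from compound 1 to compound 2 (0.14 log units; within the scatter). Compound 3, `O=C(O)c1ccccc1-c1ccc(CCc2ncc(CCc3ccccc3)[nH]2)cc1`, differs from compound 2 by benzyl in place of 4-cyanophenyl on a saturated chain carbon bound to an aromatic carbon. Among the compounds with values here, the single step that bears on this position, a 1.4-fold higher number from compound 1 to compound 2 (0.14 log units; within the scatter), stayed within the scatter, so no step beyond the scatter is expected here either. Compound 3 is therefore expected near 5000 nM, between 2000 nM and 12500 nM. The expected step is a 1.2-fold lower number from compound 2 to compound 3 (0.07 log units; within the scatter).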

Compound 3, half-maximal effective concentration: 1320 nM
Compound 3: the middle estimate sits 3.8-fold (0.58 log units) above what was measured, and the stated range ends above it.
By their numbers in this assay, from the lowest: compound 3; then compounds 1 and 2 (each within the scatter of the next).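

This position is not indifferent to the group it carries in this assay: benzyl in place of 4-cyanophenyl gives a 4.5-fold lower number from compound 2 to compound 3 (0.65 log units; beyond the scatter), and benzyl in place of 3-methylphenyl gives a 3.3-fold lower number from compound 1 to compound 3 (0.51 log units; beyond the scatter). Both modest steps lie beyond the scatter, unlike the earlier exchange between the two aryl groups. No evidence is available that accounts for this change. As far as these compounds go, it remains open whether a longer chain such as phenylpropyl, or an amine in the same place, would shift the number further.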